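The source may report more compounds than this note shows. Statements on the series, on what has been measured and on what is new or still open speak of the compounds shown alone.

Compound 1, `O=C(O)C1CCCN(CCCC=Cc2ccc(N=Nc3cccc4ccccc34)cc2)C1`, gives 1.5 h in a physicochemical assay for pharmacokinetics, read by spectrophotometry, in phosphate buffer, at pH 7.4, tested at 10 uM; on this read-out lower numbers stand for a shorter-lived compound and higher numbers for a longer-lived compound.
Compound 2, `O=C(O)C1CCCN(CCC#Cc2ccc(N=Nc3cccc4ccccc34)cc2)C1`, gives 3.4 h in this assay.

Compound 2 stands highest of the two numbers measured; its nearest neighbour is compound 1, which gives a lower number, and that gap lies beyond the usual scatter. Going by the values given here, compound 1 and compound 2 differ in more than one place, so no single step between them can be set out; only their two values are known.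

Compound 3, `O=C(O)C1CCCN(CCCC#Cc2ccc(N=Nc3cccc4ccccc34)cc2)C1`, has not yet been measured. It differs from compound 2 in one place: (3-carboxypiperidin-1-yl)methyl in place of 3-carboxypiperidin-1-yl on a saturated chain carbon, two bonds along the chain from a triple-bonded carbon. The saturated chain is extended while the triple bond and the rest of the molecule stay unchanged. Among the compounds with values here, no measured pair shows a lengthening of this chain on its own, so there is no step to lean on. The expectation for compound 3 is therefore a step from compound 2 that stays within the usual scatter, with no direction preferred, that is a 1.1-fold lower number from compound 2 to compound 3 (0.05 log units; within the scatter). Compound 3 is estimated at 3 h in this assay, with a range from 1.5 h to 6 h.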

Compound 3, half-life: 4.3 h
Beside the measured number, compound 3's estimate is 1.4-fold (0.16 log units) below it; low and high end bracket the measured number.
By their numbers in this assay, from the lowest: compound 1; then compounds 2 and 3 (each within the scatter of the next).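

Going by these compounds alone, compound 2 and compound 3 form the first pair that differs in only one place, so the effect of lengthening the saturated chain can now be read on its own. In this assay, replacing 3-carboxypiperidin-1-yl with (3-carboxypiperidin-1-yl)methyl on a saturated chain carbon, two bonds along the chain from a triple-bonded carbon, gives a 1.3-fold higher number from compound 2 to compound 3 (0.10 log units; within the scatter), so this single pair shows no effect on half-life that can be told apart from ordinary repeat variation. Nothing measured here offers an explanation for this result.

This one pair cannot show whether the same holds for a still longer chain, where the difference might or might not grow beyond the scatter, or for a chain carrying a methyl branch at this place. It also leaves open whether the half-life would stay in the same range with a methyl ester or an amide in place of the carboxylic acid, since every compound shown keeps that acid unchanged.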